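From vinyl to prop-1-en-1-yl at the assay limit

The source may report more compounds than this note shows. Statements on the series, on what has been measured and on what is new or still open speak of the compounds shown alone.

In a functional assay on B16 cells (Mus musculus) for inhibition (a lower number here means a stronger inhibitor, a higher number a weaker inhibitor), compound 1 `COc1ccc2c(COC(=O)C=C(C)C)cc(=O)oc2c1` gives > 10 ug/mL and this is a limit of the assay and not a number. Compound 2 `C=CC(=O)OCc1cc(=O)oc2cc(OC)c(OC)cc12` gives > 10 ug/mL in this assay and this is likewise only a limit. Compound 2 therefore has no exact number of its own. The evidence so far is the limit of > 10 ug/mL in this assay, at which 2 of the 2 values shown sit, and it shows no measured inhibitory strength for either compound.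

Compound 3 `C/C=C/C(=O)OCc1cc(=O)oc2cc(OC)c(OC)cc12` keeps the core of compound 2 and differs from it by prop-1-en-1-yl in place of vinyl on a carbonyl carbon with prop-1-en-1-yl in place of vinyl on a carbonyl carbon. Among the compounds with values here, no measured step shows what such a swap does here. With compound 2 at > 10 ug/mL as a limit, the expectation in this assay is for no shift beyond the usual scatter and no clear direction. The estimated step that the limit leaves unreadable from compound 2 to compound 3 is expected to stay within that scatter, and another limit reading is the likeliest result. The value expected for compound 3 is 12 ug/mL with an estimated range from 5 ug/mL to 30 ug/mL in this estimate.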

Compound 3, half-maximal inhibitory concentration: > 10 ug/mL
Compound 3: no number, only a limit; the forecaster's own chance of this, stated with the estimate: 70%; the middle value is on the limit's open side.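

Compound 2 and compound 3 both give only a limit in this assay, not a number, so no step can be read between them. The compounds shown leave open how strongly any of them inhibits and whether prop-1-en-1-yl in place of vinyl changes inhibition at all, as the evidence so far is only this: the limit of > 10 ug/mL in this assay, at which 3 of the 3 values shown sit.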